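The compounds below may be only part of what the source reports. "The series", "measured", "known", "first", "only" and "open" are said of these compounds alone.

Measured compounds in a functional assay on DU-145 cells (Homo sapiens) for antiproliferative activity, read by MTT assay, with a stated time of 48 h; on this read-out lower numbers stand for stronger inhibition and higher numbers for weaker inhibition:
Compound 1 `C/C(=C\CC/C(C)=C/CC[C@@H]1[C@@]2(C)CCC(=O)C(C)(C)[C@H]2CC[C@@]1(C)O)CC/C=C(\C)C(=O)OCc1cn(-c2ccccc2Cl)nn1` gives > 150000 nM, which is a limit of the assay rather than a number.
Compound 2 `C/C(=C\CC/C(C)=C/CC[C@@H]1[C@@]2(C)CCC(=O)C(C)(C)[C@H]2CC[C@@]1(C)O)CC/C=C(\C)C(=O)OCc1cn(-c2cccc(O)c2)nn1` gives 28400 nM.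
Compound 3 `C/C(=C\CC/C(C)=C/CC[C@@H]1[C@@]2(C)CCC(=O)C(C)(C)[C@H]2CC[C@@]1(C)O)CC/C=C(\C)C(=O)OCc1cn(-c2ccccc2C)nn1` gives > 150000 nM, again a limit of the assay rather than a number.

Compound 3 thus stands at the ceiling of what this assay reports, a position it shares with compound 1, as shown by the limit of > 150000 nM in this assay, at which 2 of the 3 values shown sit; only compound 2 gives a readable number. The change to compound 4 `C#CCOC(=O)/C(C)=C/CC/C(C)=C/CC/C(C)=C/CC[C@@H]1[C@@]2(C)CCC(=O)C(C)(C)[C@H]2CC[C@@]1(C)O` is ethynyl in place of 1-(2-methylphenyl)-1H-1,2,3-triazol-4-yl on a saturated chain carbon bound to an oxygen next to a carbonyl group. Going by the values given here, none of the measured steps touches this part of the molecule: all three swap the aromatic ring attached to the triazole. Of these, an at least 5.2-fold lower number from compound 1 to compound 2 (0.72 log units; beyond the scatter) and an at least 5.2-fold higher number from compound 2 to compound 3 (0.72 log units; beyond the scatter) show that this region can shift the read-out by at least a modest amount, while a step that the two limits leave unreadable from compound 1 to compound 3 cannot be read because both ends sit at the limit. Replacing the whole triazole and its aryl ring is a larger change than any of these, so the direction cannot be inferred from the measured steps. With two of three measured compounds at the limit, weak inhibition is expected, and the step of an at least 1.6-fold lower number from compound 3 to compound 4 (0.22 log units; that floor lies within the scatter) is an estimate rather than a measured trend. Compound 4 is therefore expected to give about 90000 nM, within a range from 25000 nM to 300000 nM, and may again return only a limit.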

Compound 4, half-maximal inhibitory concentration: 46100 nM
For compound 4 the middle estimate is 2.0-fold (0.29 log units) above the measured one; the measured number falls inside the stated range.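

In this assay, the aryl triazole is not required for a readable result at this saturated chain carbon bound to an oxygen next to a carbonyl group: ethynyl in place of 1-(2-methylphenyl)-1H-1,2,3-triazol-4-yl gives an at least 3.2-fold lower number from compound 3 to compound 4 (0.51 log units; beyond the scatter), and ethynyl in place of 1-(2-chlorophenyl)-1H-1,2,3-triazol-4-yl gives an at least 3.2-fold lower number from compound 1 to compound 4 (0.51 log units; beyond the scatter). Both steps are only minimum sizes, since compound 1 and compound 3 each return a limit of the assay rather than a number: the limit of > 150000 nM in this assay, at which 2 of the 4 values shown sit. Ethynyl in place of 1-(3-hydroxyphenyl)-1H-1,2,3-triazol-4-yl gives a 1.6-fold higher number from compound 2 to compound 4 (0.21 log units; within the scatter), so these two groups cannot be told apart here, even though ethynyl has no ring and the group it replaces has two.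

It remains open whether any group at this position can bring the read-out well below the values seen so far, since all the readable results shown lie close together. A 1H-1,2,3-triazol-4-yl group with no aryl ring, or a carboxylic acid in place of the ester, would show how much of this end of the molecule matters at all.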